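Pyrrolidin-1-yl in place of azetidin-1-yl on a carbonyl carbon

The source may hold more compounds than are shown below. What is called first, only, known or untested is meant among the compounds shown, and "the series" means these compounds.

In an ADME assay (liver) for metabolic stability, with Liver microsome (Homo sapiens) as the target, using microsomes (on this read-out higher numbers stand for fast clearance and lower numbers for slow clearance), compound 2 `Cc1cnc(NC(=O)c2cc(Oc3cnc(C(=O)N4CCC4)cn3)c3cc(C)oc3c2)cn1` reads < 9.3 mL/min/kg, which is a limit of the assay and not a number. Compound 1 `CNC(=O)c1cnc(Oc2cc(C(=O)Nc3cnc(C)cn3)cc3oc(C)cc23)cn1`, which carries methylamino in place of azetidin-1-yl on a carbonyl carbon, gives 10.1 mL/min/kg in this assay. Compound 3 `Cc1cnc(NC(=O)c2cc(Oc3cnc(C(=O)N4CCCC4)cn3)c3cc(C)oc3c2)cn1` differs from compound 2 by pyrrolidin-1-yl in place of azetidin-1-yl on a carbonyl carbon. Among the measured compounds shown here, one measured step bears on this change, the exchange at the same carbonyl carbon, which amounts to an at least 1.0-fold lower number from compound 1 to compound 2 (0.03 log units; that floor lies within the scatter). Resting on that step alone, no change beyond the scatter is expected in this assay for the new ring. The estimate is an at least 1.1-fold higher number from compound 2 to compound 3 (0.07 log units; that floor lies within the scatter), a step expected to stay small. Compound 3 is expected at 11 mL/min/kg, with an estimated range from 8 mL/min/kg to 20 mL/min/kg.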

Compound 3, clearance in the Liver microsome assay: < 8.1 mL/min/kg
Compound 3: a limit, no number (the forecaster's own chance of this, stated with the estimate: 40%); middle value at least 1.3-fold (0.13 log units) from the limit.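

In the Liver microsome assay, compound 3, with pyrrolidin-1-yl on the carbonyl carbon, gives a limit and not a number, as compound 2 with azetidin-1-yl did, so the step between these two cannot be read. Set against the methylamino amide, the change gives an at least 1.2-fold lower number from compound 1 to compound 3 (0.09 log units; that floor lies within the scatter), so this comparison does not leave the scatter either. Among the compounds shown here, what the earlier compounds did not show is that the exchange of rings can be read in another assay, where a physicochemical assay for solubility, measured as kinetic solubility (a lower number here means a less soluble compound, a higher number a more soluble compound), records a change beyond the scatter: the measured solubility of compound 2, 10000 nM, and of compound 3, 4500 nM, a 2.2-fold lower number (0.35 log units; beyond the scatter). In the physicochemical assay compound 2 gives 10000 nM and compound 3 gives 4500 nM.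

The compounds shown give no clearance number for either ring, and the true size of that difference stays open. Also open, going by these compounds, is how piperidin-1-yl or morpholin-4-yl on this carbonyl carbon would read in the Liver microsome assay and in the physicochemical assay.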